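A formyl group in place of the amide

The source may hold more compounds than are shown below. What is called first, only, known or untested is meant among the compounds shown, and "the series" means these compounds.

Compound 1, `Cc1cccc2c1nc(-c1c(F)cccc1F)n2Cc1c(F)cccc1F`, gives in a toxicity assay on CCRF-CEM cells (Homo sapiens) for cytotoxicity (a lower number here means that less compound is tolerated, a higher number that more compound is tolerated), a value that is a limit of the assay, > 100 uM.
Compound 2, `CCc1cccc2c1nc(-c1c(F)cccc1F)n2Cc1c(F)cccc1F`, gives in this assay 26.1 uM.
Compound 3, `CC(=O)N(C)c1cccc2c1nc(-c1c(F)cccc1F)n2Cc1c(F)cccc1F`, gives in this assay a value that is again a limit, > 100 uM.

Compound 3 therefore stands at the limit of > 100 uM in this assay, at which 2 of the 3 values shown sit. Compound 4, `O=Cc1cccc2c1nc(-c1c(F)cccc1F)n2Cc1c(F)cccc1F`, differs from it in one place: formyl in place of acetyl(methyl)amino on an aromatic carbon. No measured step exchanges these two groups, so the step from compound 3 to compound 4 must be read from what the same position has shown. There, an at least 3.8-fold lower number from compound 1 to compound 2 (0.58 log units; beyond the scatter), while an at least 3.8-fold higher number from compound 2 to compound 3 (0.58 log units; beyond the scatter) and a step that the two limits leave unreadable from compound 1 to compound 3. Small groups at this position thus gave both a limit and a readable number, and the amide brought the value back to the limit. Formyl is a smaller group than the one it replaces, and a readable number cannot be ruled out. Compound 4 is expected to give 70 uM, with a range from 20 uM to 150 uM, which as an expectation means an at least 1.4-fold lower number from compound 3 to compound 4 (0.15 log units; that floor lies within the scatter).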

Compound 4, half-maximal toxic concentration: 0.82 uM
For compound 4 the middle estimate is 85-fold (1.93 log units) above the measured one; the whole stated range lies above it.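

On this aromatic carbon, the earlier compounds had shown only a modest shift with ethyl, whereas formyl moves the value in this assay much further, and compounds are tolerated at far lower concentrations (an at least 120-fold lower number from compound 3 to compound 4 (2.08 log units; beyond the scatter)). The change also stands out against the two small alkyl groups, both against ethyl (a 32-fold lower number from compound 2 to compound 4 (1.50 log units; beyond the scatter)) and against methyl (an at least 120-fold lower number from compound 1 to compound 4 (2.08 log units; beyond the scatter)). Acetyl(methyl)amino and formyl carry the same counts of hydrogen-bond donors and acceptors, so these counts do not separate the two groups, and the values of compound 1 and compound 3 are limits of the assay: the limit of > 100 uM in this assay, at which 2 of the 4 values shown sit.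

From the compounds shown here alone, the true size of the two steps from those limits remains open. Also open, going by these compounds, is what sets formyl apart, and whether a hydroxymethyl group or a carboxylic acid on this carbon would give a similarly low value.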